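This account rests on a few compounds, and the source may have more. Where it says the series, first, only, none or still open, it means among the compounds named here.

Measured in a functional assay on PC-3 cells (Homo sapiens) for antiproliferative activity, read by MTT assay, with a stated time of 24 h; a higher number here means a weaker inhibitor, a lower number a stronger inhibitor:
compound 1 `CCn1c(C(=O)NCCO)ccc1C(CC)(CC)c1ccc(OCS(=O)(=O)c2ccccc2)c(C)c1`: 17700 nM
compound 2 `CCn1c(C(=O)N[C@H](CO)CCCO)ccc1C(CC)(CC)c1ccc(OCS(=O)(=O)c2ccccc2)c(C)c1`: 6810 nM

Of these two, compound 2 holds the lower number. Compound 3 `CCn1c(C(=O)NC2(C(=O)O)CC2)ccc1C(CC)(CC)c1ccc(OCS(=O)(=O)c2ccccc2)c(C)c1`, not yet measured, differs from compound 2 by a group of 6 heavy atoms (4 carbon, 2 oxygen; one three-membered non-aromatic ring of carbon only) in place of a group of 7 heavy atoms (5 carbon, 2 oxygen; no ring), on an amide-type nitrogen, which places 1-carboxycyclopropyl on the amide-type nitrogen. Within the data shown here, the only measured step, a 2.6-fold lower number from compound 1 to compound 2 (0.41 log units; beyond the scatter), also changes the group on that nitrogen and is modest. Among the measured compounds shown here, no measured compound carries 1-carboxycyclopropyl, so the direction is uncertain, but a similarly modest rise in this assay is expected. The expected change is a 2.2-fold higher number from compound 2 to compound 3 (0.34 log units; beyond the scatter). Compound 3 is estimated at 15000 nM, with an expected range of 5000 nM to 45000 nM.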

Compound 3, half-maximal inhibitory concentration: 26300 nM
Estimate against measurement, compound 3: 1.8-fold (0.24 log units) below; the range from low to high includes it.
By their numbers in this assay, from the lowest: compound 2; then compounds 1 and 3 (each within the scatter of the next).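

In this assay, 1-carboxycyclopropyl on the amide-type nitrogen, in place of the group of 7 heavy atoms, gives a 3.9-fold higher number from compound 2 to compound 3 (0.59 log units; beyond the scatter), showing that the number at this position can rise as well as fall. In place of 2-hydroxyethyl, the same group gives a 1.5-fold higher number from compound 1 to compound 3 (0.17 log units; within the scatter), so these two groups cannot be separated here. No available evidence explains either step. The compounds shown leave open how an amine or a longer chain ending in a carboxylic acid on this nitrogen would read, and whether the defined stereocentre in compound 2 matters.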